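One unmeasured step: compound 2 to compound 4

The compounds below may be only part of what the source reports. "The series", "measured", "known", "first", "only" and "open" are said of these compounds alone.

Compound 1 `CC1=CC[C@@H]([C@@](C)(O)CCCC(C)(C)NC(=S)NN)CC1`: 18500 nM
Compound 2 `COc1ccc(/C=N\NC(=S)NC(C)(C)CCC[C@](C)(O)[C@@H]2CC=C(C)CC2)cc1`: 7420 nM
Compound 3 `CC1=CC[C@@H]([C@@](C)(O)CCCC(C)(C)NC(=S)N/N=C\c2ccc(N(C)C)cc2)CC1`: > 100000 nM

All three were tested in a functional assay on UACC-62 cells (Homo sapiens) for cytotoxicity, read by sulforhodamine B assay (a lower number here means a stronger inhibitor of growth, a higher number a weaker inhibitor of growth), on the same scale. Compound 3 gives only a limit of the assay at > 100000 nM and no number. Compound 2 at 7420 nM has the lower of the two true numbers, and compound 1 is its nearest neighbour.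

Compound 4 `CC1=CC[C@@H]([C@@](C)(O)CCCC(C)(C)NC(=S)N/N=C(/C)c2ccccc2)CC1` has not yet been measured. The change from compound 2 is a group of 9 heavy atoms (8 carbon, 1 nitrogen; one six-membered aromatic ring of carbon only) in place of a group of 10 heavy atoms (8 carbon, 1 nitrogen, 1 oxygen; one six-membered aromatic ring of carbon only), on an amide-type nitrogen and it falls on an amide-type nitrogen with a thiocarbonyl carbon as its other neighbour.

Within the data shown here, two measured steps bear on it. One is a 2.5-fold lower number from compound 1 to compound 2 (0.40 log units; beyond the scatter) on the arrival of the group of 10 heavy atoms in place of one nitrogen atom, which is a modest step. The other is an at least 13-fold higher number from compound 2 to compound 3 (1.12 log units; beyond the scatter) with dimethylamino in place of methoxy on an aromatic carbon, which is a large step. Among the measured compounds shown here, the only measured change made to compound 2 therefore raised the number, so a modest rise is expected here, though with wide uncertainty. The expected size is a 2.2-fold higher number from compound 2 to compound 4 (0.33 log units; beyond the scatter) in this assay as estimated from these two steps. Compound 4 is estimated at 16000 nM with an expected range from 4500 nM to 60000 nM in this assay.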

Compound 4, concentration for 50% growth inhibition: 22400 nM
Compound 4: the middle estimate sits 1.4-fold (0.15 log units) below what was measured; the measured number falls inside the stated range.
By their numbers in this assay, from the lowest: compound 2; then compounds 1 and 4 (each within the scatter of the next). At a limit, above all of these: compound 3.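

In this assay, the lower number of compound 2 turns out not to follow from just any aromatic group on the amide-type nitrogen: the step is a 1.2-fold higher number from compound 1 to compound 4 (0.08 log units; within the scatter), so the group of 9 heavy atoms, with its six-membered aromatic ring of carbon only, cannot be told apart from the single nitrogen atom it replaces. The group of 10 heavy atoms, by contrast, stands apart with a 3.0-fold higher number from compound 2 to compound 4 (0.48 log units; beyond the scatter), so at this position the outcome depends on the exact make-up of the aromatic group, and compounds 3 and 4 go against any rule that such a group lowers the number. Compound 3 remains a limit of the assay and gives no number to set against the others: the limit of > 100000 nM in this assay, at which 1 of the 4 values shown sits.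

The two groups differ in more than one feature, so the step from compound 2 to compound 4 does not show which feature carries the difference. Also open, as far as these compounds go, is whether a hydroxyl, a chlorine or a nitro group in place of methoxy on an aromatic carbon would keep the number of compound 2 7420 nM or lose it.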